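A few compounds are considered here, and "the series" means these few. Any claim that something is new, unique, unknown or untested is made for them only; others in the source may bear on it.

Three compounds with a shared core were tested in an assay on isolated protein for inhibition of Dihydrofolate reductase (Homo sapiens), read by spectrophotometry, using NADPH, with stated times of 5 s and 6 min, tested at 50 uM; a lower number here means a weaker effect, a higher number a stronger effect of the compound at the concentration tested. Compound 1 `NC1=NC2(CCSCC2)N(OCCCOc2cccc(Cl)c2Cl)C(N)=N1` gives 89.8% in this assay, compound 2 `NC1=NC2(CCSCC2)N(OCCCOc2cc(Cl)c(Cl)cc2Cl)C(N)=N1` gives 94.4%, and compound 3 `NC1=NC2(CCSCC2)N(OCCCOc2ccccc2Br)C(N)=N1` gives 89.6%. The differences between them lie only in the halogenated phenyl group on an oxygen on a saturated carbon. Going a number 4.6 percentage points higher from compound 1 to compound 2 (within the scatter), a number 0.2 percentage points lower from compound 1 to compound 3 (within the scatter) and a number 4.8 percentage points lower from compound 2 to compound 3 (within the scatter), every one of these steps stays within the scatter, so compound 3 cannot be said to stand apart from compound 1 or compound 2; the three numbers are indistinguishable.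

Compound 4 `NC1=NC2(CCSCC2)N(OCCCOc2cccc(Br)c2)C(N)=N1` is not yet measured. It differs from compound 3 by 3-bromophenyl in place of 2-bromophenyl on an oxygen on a saturated carbon. The bearing steps are those that swap one halogenated phenyl for another at the same place, and none of them moved the number beyond the scatter. The move of the bromine from one position on the ring to another is therefore expected to give a number 0.4 percentage points higher from compound 3 to compound 4 (within the scatter), that is, no change beyond the scatter. Compound 4 is estimated at 90% in this assay, with a range from 80% to 97%.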

Compound 4, a percentage reported as inhibition, at one concentration (the size of the read-out at that concentration, not a potency): 86.5%
Beside the measured number, compound 4's estimate is 3.5 percentage points above it, within the range that was stated.
By their numbers in this assay, from the lowest: compounds 4, 3, 1 and 2 (each within the scatter of the next).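

Earlier swaps at this place replaced one halogenated phenyl group with another, whereas this change only moves the bromine on the ring, 3-bromophenyl in place of 2-bromophenyl, and the number stays within the scatter in this assay (a number 3.1 percentage points lower from compound 3 to compound 4 (within the scatter)). The steps from the two chlorinated compounds also stay within the scatter (a number 3.3 percentage points lower from compound 1 to compound 4 (within the scatter); a number 7.9 percentage points lower from compound 2 to compound 4 (within the scatter)), so neither this move of the bromine nor the halogen pattern separates these compounds. Nothing available explains these numbers.

These read-outs come from a single concentration and are not potencies, so differences in potency could remain hidden among the compounds. Going by these compounds, it also remains open how the number would respond to a phenyl group carrying an amine or a carboxylic acid, or to a longer chain at this place.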